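The source may hold more compounds than are shown below. What is called first, only, known or untested is meant among the compounds shown, and "the series" means these compounds.

Working notes on the series. Compound 1 `O=C(O)CCCC(=O)OCCOc1no[n+]([O-])c1S(=O)(=O)c1ccccc1` carries a 3-carboxypropyl group on a carbonyl carbon; in a functional assay on HepG2 cells (Homo sapiens) for antiproliferative activity, read by MTT assay, with a stated time of 72 h (on this read-out lower numbers stand for stronger inhibition and higher numbers for weaker inhibition), compound 1 gives 4000 nM. Compound 2 `O=C(O)CCCC(=O)OCCCOc1no[n+]([O-])c1S(=O)(=O)c1ccccc1` carries the same group, but the difference between the core of compound 2 and the core of compound 1 is not broken down here. In this assay compound 2 reaches only the limit of the assay, > 10000 nM. Compound 3 `O=C(O)c1ccccc1C(=O)OCCOc1no[n+]([O-])c1S(=O)(=O)c1ccccc1` is compound 1 after the change (2-carboxyphenyl in place of 3-carboxypropyl on a carbonyl carbon). In this assay compound 3 likewise gives only a limit, > 10000 nM. The step from compound 1 is therefore an at least 2.5-fold higher number from compound 1 to compound 3 (0.39 log units; beyond the scatter), and its true size is open at the top because the limit of > 10000 nM in this assay, at which 2 of the 3 values shown sit, caps what the assay can report.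

Compound 4 `O=C(O)c1ccccc1C(=O)OCCCOc1no[n+]([O-])c1S(=O)(=O)c1ccccc1` is not yet measured. It stands to compound 2 as compound 3 stands to compound 1, the same change at the same place: 2-carboxyphenyl in place of 3-carboxypropyl on a carbonyl carbon. Within the data shown here, the only measured instance of this change weakened the read-out, as an at least 2.5-fold higher number from compound 1 to compound 3 (0.39 log units; beyond the scatter) shows, and the starting point, compound 2, already sits at the limit.

The step from compound 2 to compound 4 in this assay is expected to be a step that the limit leaves unreadable from compound 2 to compound 4, resting on the measured step of an at least 2.5-fold higher number from compound 1 to compound 3 (0.39 log units; beyond the scatter) and on compound 2 starting at a limit. Compound 4 is expected to give about 15000 nM, estimated between 8000 nM and 40000 nM, and most probably to be reported only as a limit again.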

Compound 4, half-maximal inhibitory concentration: > 10000 nM
Compound 4: no number, only a limit; the forecaster's own chance of this, stated with the estimate: 85%; the middle value is on the limit's open side.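

In this assay compound 4 gives > 10000 nM, which is a limit and not a number. With compound 2 also at a limit, no step can be read between compound 2 and compound 4: the limit of > 10000 nM in this assay, at which 3 of the 4 values shown sit.

The compounds shown leave open whether 2-carboxyphenyl in place of 3-carboxypropyl on a carbonyl carbon changes the read-out on the core of compound 2 as it does on the core of compound 1.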